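Cyclohexyl substituent swap in the amine series

The source may report more compounds than this note shows. Statements on the series, on what has been measured and on what is new or still open speak of the compounds shown alone.

In a functional assay on cells for agonist activity at C-X-C chemokine receptor type 4 (Homo sapiens), read by fluorescence and calcium flux, with a stated time of 90 s (a higher number here means that more compound is needed for the effect, a lower number that less compound is needed), compound 1 `c1cncc(CNCCCCN(C[C@H]2Cc3ccccc3CN2)[C@H]2CCCc3cccnc32)c1` returns only a limit of the assay, > 30000 nM. Compound 2 `FC1(F)CCC(NC/C=C/CN(C[C@H]2Cc3ccccc3CN2)[C@H]2CCCc3cccnc32)CC1` likewise gives only a limit in this assay, > 30000 nM. Within the data shown here, compound 2 thus stands at the limit of > 30000 nM in this assay, at which 2 of the 2 values shown sit, and no measured step from it exists. Compound 3 `CC1(C)CCC(NC/C=C/CN(C[C@H]2Cc3ccccc3CN2)[C@H]2CCCc3cccnc32)CC1` differs from compound 2 by 4,4-dimethylcyclohexyl in place of 4,4-difluorocyclohexyl on an amine nitrogen. With both shown results at the ceiling, no step beyond the scatter is expected in either direction, and a further limit is the most likely outcome. The expected step is a step that the limit leaves unreadable from compound 2 to compound 3. Compound 3 is estimated at 40000 nM, within 12000 nM to 150000 nM.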

Compound 3, half-maximal effective concentration: > 30000 nM
Compound 3: only a limit was reported; the forecaster's own chance of this, stated with the estimate: 75%; the middle value does not contradict the limit.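

Among these compounds, compound 2 and compound 3 both return only a limit in this assay, so no step between them can be read. The compounds shown leave open how 4,4-dimethylcyclohexyl and 4,4-difluorocyclohexyl compare, and what structure gives a measurable value.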